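Bromo to methoxy on the benzyl ether arm

The source may hold more compounds than are shown below. What is called first, only, known or untested is meant among the compounds shown, and "the series" means these compounds.

Among the compounds with values here, compound 1 `Cc1cc(Br)cc(COC[C@@H](N)c2ccccc2)c1` has been measured in an assay on isolated protein for binding affinity to Substance-P receptor (Homo sapiens) (on this read-out lower numbers stand for stronger inhibition and higher numbers for weaker inhibition), where compound 1 gives 20 nM, the only single number. Compound 2 `CC(OCc1cc(C(F)(F)F)cc(C(F)(F)F)c1)C(N)c1ccccc1` appears in this assay with more than one entry; compound 2 gives 95 nM; 7 nM (2 entries). Within the data shown here, no step between measured compounds is available. Compound 3 `COc1cc(C)cc(COC[C@@H](N)c2ccccc2)c1` is not yet measured; it differs from compound 1 by methoxy in place of bromo on an aromatic carbon. For compound 3 a moderate loss beyond the scatter is expected, a 3.0-fold higher number from compound 1 to compound 3 (0.48 log units; beyond the scatter). Compound 3 is therefore estimated at 60 nM, between 15 nM and 250 nM.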

Compound 3, half-maximal inhibitory concentration: 135 nM
For compound 3 the middle estimate is 2.3-fold (0.35 log units) below the measured one, within the range that was stated.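

In this assay, within the data shown here, methoxy in place of bromo on this aromatic carbon gives a 6.8-fold higher number from compound 1 to compound 3 (0.83 log units; beyond the scatter), the first readable step, so the two groups are not interchangeable at this place. The change adds a hydrogen-bond acceptor and one more heavy atom, and this single pair cannot separate those two differences. One pair is thin support, since entries for a single compound in this assay can differ widely: the several entries of compound 2 in this assay, 95 nM; 7 nM (2 entries)

Still open, on these data alone, is how chloro, a hydroxyl or a longer ether chain such as ethoxy would stand at this place on the core of compound 1.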